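From pyridin-3-yl to 4-chlorophenyl on the carbonyl carbon

This account rests on a few compounds, and the source may have more. Where it says the series, first, only, none or still open, it means among the compounds named here.

Compound 2 `O=C(c1cccnc1)n1c(-c2cn(-c3ccccc3)nc2-c2ccc(F)cc2)nc2ccccc21` was tested in an ADME assay on HEK-293T cells (Homo sapiens) for cytotoxicity, read by MTT assay, with a stated time of 24 h (on this read-out higher numbers stand for lower toxicity in this test and lower numbers for higher toxicity in this test), where compound 2 gives 216000 nM. Within the data shown here, of the two numbers measured so far this is the highest, and its nearest neighbour is compound 1 `Cc1ccc(C(=O)n2c(-c3cn(-c4ccccc4)nc3-c3ccc(F)cc3)nc3ccccc32)cc1`, which in this assay gives 178000 nM; the step of a 1.2-fold higher number from compound 1 to compound 2 (0.08 log units; within the scatter) is within the scatter, so the two cannot be told apart. Compound 3 `O=C(c1ccc(Cl)cc1)n1c(-c2cn(-c3ccccc3)nc2-c2ccc(F)cc2)nc2ccccc21` differs from compound 2 in one place: 4-chlorophenyl in place of pyridin-3-yl on a carbonyl carbon. Among the measured compounds shown here, only one measured step bears on this change, a 1.2-fold higher number from compound 1 to compound 2 (0.08 log units; within the scatter), since it too exchanges the group on the carbonyl carbon, and it stayed within the scatter. An exchange of the same kind is therefore expected to move the number little, in no clear direction. Compound 3 is expected to give about 200000 nM in this assay, with a range from 100000 nM to 400000 nM, which means an estimated step of a 1.1-fold lower number from compound 2 to compound 3 (0.03 log units; within the scatter).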

Compound 3, half-maximal cytotoxic concentration: 179000 nM
The estimate for compound 3 lay 1.1-fold (0.05 log units) above the measured number; low and high end bracket the measured number.
By their numbers in this assay, from the lowest: compounds 1, 3 and 2 (each within the scatter of the next).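

On the carbonyl carbon, the three six-membered aromatic rings pyridin-3-yl, 4-methylphenyl and 4-chlorophenyl cannot be told apart in this assay: exchanging pyridin-3-yl for 4-chlorophenyl gives a 1.2-fold lower number from compound 2 to compound 3 (0.08 log units; within the scatter), and chloro in place of methyl on an aromatic carbon gives a 1.0-fold higher number from compound 1 to compound 3 (0.00 log units; within the scatter). Removing the ring nitrogen with its hydrogen-bond acceptor and adding a chlorine therefore leaves the number within the scatter in these compounds. Nothing measured here gives a reason for this result.

From the compounds shown here alone, all three groups are six-membered aromatic rings, so it remains open whether a longer chain on the carbonyl carbon, or an amine or carboxylic acid on the ring, would also stay within the scatter. Going by these compounds, the shared core is the same throughout, so the effect of exchanges elsewhere on it is open too.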